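Triazole-linked sulfonamides: triazole N-aryl variation

This account rests on a few compounds, and the source may have more. Where it says the series, first, only, none or still open, it means among the compounds named here.

Measured compounds:
- compound 1 `O=c1[nH]cc(S(=O)(=O)Nc2ccccc2-c2cn(-c3ccccc3)nn2)c(=O)[nH]1`: 6790 nM
- compound 2 `Cc1ccc(-n2cc(-c3ccccc3NS(=O)(=O)c3c[nH]c(=O)[nH]c3=O)nn2)cc1`: 2910 nM
- compound 3 `O=c1[nH]cc(S(=O)(=O)Nc2ccccc2-c2cn(-c3ccccc3F)nn2)c(=O)[nH]1`: 7370 nM

In a functional assay on A549 cells (Homo sapiens) for antiproliferative activity, read by MTT assay, with a stated time of 24 h (on this read-out higher numbers stand for weaker inhibition and lower numbers for stronger inhibition), compound 2 gives the lowest of the three numbers, and both of its steps are beyond the scatter: a 2.3-fold lower number from compound 1 to compound 2 (0.37 log units; beyond the scatter) and a 2.5-fold higher number from compound 2 to compound 3 (0.40 log units; beyond the scatter). The unmeasured compound 4 `O=c1[nH]cc(S(=O)(=O)Nc2ccccc2-c2cn(-c3ccccc3Cl)nn2)c(=O)[nH]1` differs from compound 2 in one place: 2-chlorophenyl in place of 4-methylphenyl on an aromatic nitrogen.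

For the measured compounds named here, two measured steps bear on this change. The step of a 2.5-fold higher number from compound 2 to compound 3 (0.40 log units; beyond the scatter) covers the same leaving group and a halogen entering at the same position of the phenyl ring on the triazole nitrogen. The step of a 1.1-fold higher number from compound 1 to compound 3 (0.04 log units; within the scatter) shows that the halogen at that position, against hydrogen, made no difference beyond the scatter. Going by the values given here, nothing among the measured compounds separates chloro from fluoro here, so compound 4 is expected to sit near compound 1 and compound 3 rather than near compound 2, which means a step upward of roughly a 2.2-fold higher number from compound 2 to compound 4 (0.35 log units; beyond the scatter).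

Compound 4 is therefore estimated at 6500 nM in this assay, with a range from 3000 nM to 14000 nM.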

Compound 4, half-maximal inhibitory concentration: 2740 nM
Beside the measured number, compound 4's estimate is 2.4-fold (0.38 log units) above it, outside the stated range (below it).
By their numbers in this assay, from the lowest: compounds 4 and 2 (each within the scatter of the next); then compounds 1 and 3 (each within the scatter of the next).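

Halogen identity matters on this phenyl ring in this assay: chloro in place of fluoro gives a 2.7-fold lower number from compound 3 to compound 4 (0.43 log units; beyond the scatter), and chloro in place of hydrogen gives a 2.5-fold lower number from compound 1 to compound 4 (0.39 log units; beyond the scatter), whereas fluoro in place of hydrogen had shown no change beyond the scatter. 2-Chlorophenyl in place of 4-methylphenyl on the aromatic nitrogen gives a 1.1-fold lower number from compound 2 to compound 4 (0.03 log units; within the scatter), so two differently substituted phenyl groups now stand level, both apart from the phenyl and 2-fluorophenyl compounds. No available evidence accounts for the separation of chloro from fluoro.

The compounds shown do not separate the identity of the group from its place on the ring, a question on which 4-chlorophenyl and 2-methylphenyl would bear. As far as these compounds go, whether the trend continues to 2-bromophenyl, or holds for an amine such as 2-aminophenyl, also remains open.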